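This account rests on a few compounds, and the source may have more. Where it says the series, first, only, none or still open, it means among the compounds named here.

Of the compounds shown here, two of a shared core have been measured in an assay on cell membranes for displacement of a labelled ligand from Alpha-1A adrenergic receptor (Rattus norvegicus); on this read-out lower numbers stand for stronger inhibition and higher numbers for weaker inhibition. Compound 1 `Cc1ccc2c(c1)c(-c1ccc(F)cc1)cn2C1CCN(CCN2CCN(C(C)C)C2=O)CC1` gives 280 nM in this assay. Compound 2 `Cc1ccc2c(c1)c(-c1ccc(F)cc1)cn2C1=CCN(CCN2CCNC2=O)CC1`, whose side chain carries a plain cyclic urea and whose piperidine ring holds a double bond, gives 24 nM in this assay. Compound 2 thus stands with the lowest of the two numbers, and compound 1 sits a clear distance away, beyond the usual scatter of repeated runs.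

From compound 2 the next compound, compound 3 `Cc1ccc2c(c1)c(-c1ccc(F)cc1)c(C)n2C1=CCN(CCN2CCNC2=O)CC1`, is reached by one change: methyl in place of hydrogen on an aromatic carbon. The methyl sits on the five-membered aromatic ring of the shared core, next to the ring nitrogen and next to the ring atom that bears the 4-fluorophenyl group.

For the measured compounds named here, no pair of measured compounds differs by a single change, so there is no measured step that this one can be set against. The step from compound 2 to compound 3 is expected to be modest, a 1.9-fold higher number from compound 2 to compound 3 (0.27 log units; within the scatter), leaning toward a somewhat weaker binding. Compound 3 is therefore expected to give about 45 nM in this assay, within a range from 12 nM to 160 nM.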

Compound 3, half-maximal inhibitory concentration: 1000 nM
Estimate against measurement, compound 3: 22-fold (1.35 log units) below; measured number outside the range, above it.
By their numbers in this assay, from the lowest: compound 2; then compound 1; then compound 3.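

In this assay, the aromatic carbon next to the ring nitrogen and next to the ring atom that bears a 4-fluorophenyl group proves far from indifferent to substitution: methyl in place of hydrogen there gives a 42-fold higher number from compound 2 to compound 3 (1.62 log units; beyond the scatter) and so marks a large loss of binding. For the compounds shown here, this is the first single-change step, and it shows that one added carbon on the five-membered aromatic ring of the shared core, bringing no hydrogen-bond donor or acceptor and no net charge, is enough to move the number well beyond the scatter. No measurement in hand bears on why this methyl has so large an effect.

The compounds shown leave open whether the loss is particular to methyl or would also follow from a fluorine atom, an ethyl group or a hydroxymethyl group on the same carbon. They also leave open whether the same methyl would have as large an effect in a compound with a saturated piperidine ring or with an isopropyl group on the cyclic urea.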